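Formamide series against horse liver alcohol dehydrogenase: next step

This account rests on a few compounds, and the source may have more. Where it says the series, first, only, none or still open, it means among the compounds named here.

Measured so far:
compound 1, `CCCCCCc1ccc(CNC=O)cc1` — 26.3 nM
compound 2, `CCCCCCc1cn[nH]c1` — 1.32 nM
compound 3, `O=CNCc1ccc(O)cc1` — 1780 nM

All three numbers come from an assay for inhibition of alcohol dehydrogenase (Equus caballus); on this read-out higher numbers stand for weaker inhibition and lower numbers for stronger inhibition. Compound 3 stands at the highest number of the three. Its nearest neighbour is compound 1, whose number is lower by a margin beyond the scatter, and compound 2 sits further away still, also beyond the scatter. Compound 3 is therefore the weakest inhibitor of the three. Compound 1 is the closest point of comparison: the two share the same core and differ only in the group on the aromatic ring.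

The next compound, compound 4, `CCCCCOc1ccc(CNC=O)cc1`, is reached from compound 3 by one change: pentyl in place of hydrogen on an oxygen on an aromatic ring. Among the measured compounds shown here, no step between two measured compounds covers exactly this change, so the expectation rests on what compound 1 and compound 3 show. Compound 1 carries a long chain on the same ring and gives 26.3 nM, whereas compound 3 carries only a hydroxyl there and gives 1780 nM. A chain of five carbons entering on the oxygen is expected to move compound 4 down toward the number of compound 1, a large step beyond the scatter, which my estimate puts at a 59-fold lower number from compound 3 to compound 4 (1.77 log units; beyond the scatter). The estimate for compound 4 in this assay is 30 nM, within a range from 8 nM to 120 nM.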

Compound 4, inhibition constant: 30.2 nM
For compound 4 the middle estimate is 1.0-fold (0.00 log units) below the measured one; measured number inside the range.
By their numbers in this assay, from the lowest: compound 2; then compounds 1 and 4 (each within the scatter of the next); then compound 3.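

Working notes: in this assay, pentyl in place of hydrogen on an oxygen on an aromatic ring gives a 59-fold lower number from compound 3 to compound 4 (1.77 log units; beyond the scatter) and is the only step in the series that can be read so far, so at this position the hydrogen on that oxygen is not required for strong inhibition, and a large gain comes with the pentyl chain. Compound 1 at 26.3 nM and compound 4 at 30.2 nM lie within the scatter of each other, so the long chain on the ring of compound 1 and the pentyl chain held through oxygen in compound 4 cannot be told apart on this read-out. Nothing available explains the size of this step.

Open, from the compounds shown here alone, is how the number depends on the chain on this oxygen: whether methyl or butyl keeps part of the step, and whether a longer chain such as octyl extends it or loses it. Also open, going by these compounds, is how the position takes a chain ending in something other than carbon, such as an amine or a carboxylic acid, or a benzyl group in place of pentyl.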